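A few compounds are considered here, and "the series" means these few. Any claim that something is new, unique, unknown or untested is made for them only; others in the source may bear on it.

Two chalcones with a shared core have been measured in a functional assay on CAKI-1 cells (Homo sapiens) for inhibition; on this read-out lower numbers stand for stronger inhibition of growth and higher numbers for weaker inhibition of growth: compound 1 `COc1cc(/C=C/C(=O)c2cccc(-n3cc(-c4ccccc4)[nH]c3=O)c2)cc(OC)c1OC` gives 1750 nM, and compound 2 `COc1ccc(-c2cn(-c3cccc(C(=O)/C=C/c4cc(OC)c(OC)c(OC)c4)c3)c(=O)[nH]2)cc1` gives 3050 nM. Compound 2 stands at the larger of these two numbers, yet the step of a 1.7-fold higher number from compound 1 to compound 2 (0.24 log units; within the scatter) lies within the scatter, so the pair is not separated. Compound 3 `COc1cc(/C=C/C(=O)c2cccc(-n3cc(-c4cc(OC)c(OC)c(OC)c4)[nH]c3=O)c2)cc(OC)c1OC` carries 3,4,5-trimethoxyphenyl in place of 4-methoxyphenyl on an aromatic carbon. Among the measured compounds shown here, the only step that bears on this change is the one from compound 1 to compound 2, and it stayed within the scatter, so no shift beyond the scatter is expected in this assay. Compound 3 is therefore estimated at 3000 nM, with a range of 1200 nM to 7500 nM, which means an expected step of a 1.0-fold lower number from compound 2 to compound 3 (0.01 log units; within the scatter).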

Compound 3, concentration for 50% growth inhibition: 2890 nM
Compound 3: middle estimate off by 1.0-fold (0.02 log units), on the high side; measured number inside the range.
By their numbers in this assay, from the lowest: compounds 1, 3 and 2 (each within the scatter of the next).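

In this assay, 3,4,5-trimethoxyphenyl in place of 4-methoxyphenyl on an aromatic carbon of the five-membered ring gives a 1.1-fold lower number from compound 2 to compound 3 (0.02 log units; within the scatter), and in place of phenyl it gives a 1.7-fold higher number from compound 1 to compound 3 (0.22 log units; within the scatter). Phenyl, 4-methoxyphenyl and 3,4,5-trimethoxyphenyl are thus not separated at this position, even with 12 heavy atoms and 3 hydrogen-bond acceptors in the entering group against 8 and 1 in the group it replaces. Nothing available accounts for this flat result. On these data alone, whether an amine or a carboxylic acid on this carbon would shift the number beyond the scatter remains open.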